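The source may report more compounds than this note shows. Statements on the series, on what has been measured and on what is new or still open speak of the compounds shown alone.

Measured so far in a functional assay on MCF7 cells (Homo sapiens) for cytotoxicity, read by CellTiter-Glo, with a stated time of 5 days; on this read-out higher numbers stand for weaker inhibition and lower numbers for stronger inhibition:
- compound 1 `CC/C(=C(/c1ccc(/C=C/C(=O)O)cc1)c1ccc2[nH]ncc2c1)c1cccc(Cl)c1`: 12 nM
- compound 2 `CC/C(=C(/c1ccc(/C=C/C(=O)O)cc1)c1ccc2[nH]ncc2c1)c1cccnc1C`: 200 nM
- compound 3 `CC/C(=C(/c1ccc(/C=C/C(=O)O)cc1)c1ccc2[nH]ncc2c1)c1ccncc1C`: 16 nM

Compound 3 stands level with compound 1, as a 1.3-fold higher number from compound 1 to compound 3 (0.12 log units; within the scatter) shows, and well clear of compound 2, as a 13-fold lower number from compound 2 to compound 3 (1.10 log units; beyond the scatter) shows. Compound 2 is the weakest of the three.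

The next step leads to compound 4 `CC/C(=C(/c1ccc(/C=C/C(=O)O)cc1)c1ccc2[nH]ncc2c1)c1cscc1C`: 4-methylthiophen-3-yl in place of 3-methylpyridin-4-yl on a double-bonded chain carbon bound to a double-bonded chain carbon and a saturated chain carbon.

All three measured steps change the group at this same place. Two of them are large, a 17-fold higher number from compound 1 to compound 2 (1.22 log units; beyond the scatter) and a 13-fold lower number from compound 2 to compound 3 (1.10 log units; beyond the scatter), and both involve compound 2. Compound 2 therefore goes against any reading that this place tolerates change freely. Among the compounds with values here, no measured compound carries a five-membered ring here, so the data only loosely bound this step.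

With compound 3 at 16 nM and compound 1 at 12 nM as the nearest guides, no step beyond the scatter is expected in this assay, though the risk lies towards higher numbers. The expected step is a 1.3-fold higher number from compound 3 to compound 4 (0.10 log units; within the scatter). The estimate for compound 4 is 20 nM, with an expected range of 6 nM to 80 nM.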

Compound 4, half-maximal inhibitory concentration: 2 nM
Beside the measured number, compound 4's estimate is 10-fold (1.00 log units) above it; the measured number lies below the stated range.
By their numbers in this assay, from the lowest: compound 4; then compounds 1 and 3 (each within the scatter of the next); then compound 2.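

Notes on the group on the double-bonded chain carbon bound to a double-bonded chain carbon and a saturated chain carbon, read in this assay: a five-membered aromatic ring is not merely tolerated here, since 4-methylthiophen-3-yl goes beyond both low-number six-membered groups (an 8.0-fold lower number from compound 3 to compound 4 (0.90 log units; beyond the scatter); a 6.0-fold lower number from compound 1 to compound 4 (0.78 log units; beyond the scatter)). The spread at this one place now reaches a much wider span (a 100-fold lower number from compound 2 to compound 4 (2.00 log units; beyond the scatter)), and compound 4 stands clear of all the others in this assay. No measurement shown accounts for this gain.

Whether the ring methyl contributes stays open, as the compounds shown include no unsubstituted thiophen-3-yl group. From the compounds shown here alone, it is also open whether sulfur matters or the five-membered ring alone is enough, as none of them carries a 4-methylfuran-3-yl group at this place.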